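The source may hold more compounds than are shown below. What is called first, only, known or untested is meant among the compounds shown, and "the series" means these compounds.

In a functional assay on MCF7 cells (Homo sapiens) for cytotoxicity, read by MTT assay, with a stated time of 72 h (on this read-out lower numbers stand for stronger inhibition and higher numbers for weaker inhibition), two compounds have a reading so far. Compound 1 (`CCOC(=O)C1=C(C)NC(=S)NC1c1cn(C(=O)CNc2ccc([N+](=O)[O-])c(Cl)c2)c2ccccc12`) gives 50 ug/mL, and compound 2 (`CCOC(=O)C1=C(C)NC(=O)NC1c1cn(C(=O)CNc2ccc([N+](=O)[O-])cc2Cl)c2ccccc12`) gives 50 ug/mL, so compound 2 stands level with compound 1. The next compound, compound 3 (`CCOC(=O)C1=C(C)NC(=O)NC1c1cn(C(=O)CNc2ccc([N+](=O)[O-])cc2)c2ccccc12`), departs from compound 2 in one place only: hydrogen in place of chloro on an aromatic carbon. Put simply, hydrogen takes the place of chloro on an aromatic carbon, turning 2-chloro-4-nitrophenyl into 4-nitrophenyl. For the measured compounds named here, no two measured compounds differ in one place only, so the data offer no direct guide to this swap. For that reason, no step beyond the usual scatter is expected in this assay, in either direction. The expected step is no change at the digits printed from compound 2 to compound 3 (within the scatter). Compound 3 is therefore estimated at 50 ug/mL, with an expected range from 20 ug/mL to 110 ug/mL.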

Compound 3, half-maximal inhibitory concentration: > 1000 ug/mL
Compound 3 ended at the assay's limit (the forecaster's own chance of this, stated with the estimate: 15%); middle value at least 20-fold (1.30 log units) away from the limit.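

In this assay, hydrogen in place of chloro on this aromatic carbon, ortho to a large group and meta to a nitro group, gives an at least 20-fold higher number from compound 2 to compound 3 (1.30 log units; beyond the scatter), a move towards much weaker inhibition from the loss of a single chlorine atom. For the compounds shown here, no earlier pair differed in one place only, so this is the first direct sign that the series responds strongly to a small change, and that this position matters. The reading for compound 3 is a limit of the assay and not a number: the limit of > 1000 ug/mL in this assay, at which 1 of the 3 values shown sits.

Still open, going by these compounds, is whether chloro itself is needed, or whether another group on the same carbon, such as fluoro, bromo or methyl, would serve as well. Also open, on these data alone, is whether the same swap would have a similar effect on the core of compound 1.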